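Ring Size and Alkyl Length at a Charged Nitrogen

This account rests on a few compounds, and the source may have more. Where it says the series, first, only, none or still open, it means among the compounds named here.

Compound 1 `Cc1cc(-n2cc(C(=O)Nc3cc(F)cc(F)c3)c(=O)c3ccc(N(C)C)nc32)ccc1OCCCCCCC[N+]12CCN(CC1)CC2`: 10.6%
Compound 2 `Cc1cc(-n2cc(C(=O)Nc3cc(F)cc(F)c3)c(=O)c3ccc(N(C)C)nc32)ccc1OCCCCCCC[N+]1(C)CCCC1`: 26.1%
Compound 3 `Cc1cc(-n2cc(C(=O)Nc3cc(F)cc(F)c3)c(=O)c3ccc(N(C)C)nc32)ccc1OCCCCCCC[N+]1(C)CCCCC1`: 33%

In an assay on LX2 cells for inhibition of COL1A1 promoter (Homo sapiens), read by a luciferase reporter, with a stated time of 24 h, tested at 20 uM (a lower number here means a weaker effect, a higher number a stronger effect of the compound at the concentration tested), compound 3 gives 33%, the highest of the three numbers. Of the steps leading to it, a number 6.9 percentage points higher from compound 2 to compound 3 (within the scatter) lies within the scatter, whereas a number 22.4 percentage points higher from compound 1 to compound 3 (beyond the scatter) and a number 15.5 percentage points higher from compound 1 to compound 2 (beyond the scatter) lie beyond it. All three measured steps exchange the ring on the charged nitrogen at the chain end.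

Compound 4 `CC[N+]1(CCCCCCCOc2ccc(-n3cc(C(=O)Nc4cc(F)cc(F)c4)c(=O)c4ccc(N(C)C)nc43)cc2C)CCCCC1` differs from compound 3 by methyl in place of hydrogen on a saturated chain carbon bound to an amine nitrogen in a ring. Among the compounds with values here, no measured step touches this small group; the ring on the nitrogen stays as in compound 3. With nothing pointing either way, compound 4 is expected to show a step of a number 3 percentage points higher from compound 3 to compound 4 (within the scatter), within the scatter. Compound 4 is therefore estimated at 36%, with a range from 20% to 52%.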

Compound 4, a percentage reported as inhibition, at one concentration (the size of the read-out at that concentration, not a potency): 19.7%
Beside the measured number, compound 4's estimate is 16.3 percentage points above it, outside the stated range (below it).
By their numbers in this assay, from the lowest: compounds 1, 4, 2 and 3 (each within the scatter of the next, the first and the last beyond it).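

On the saturated chain carbon bound to an amine nitrogen in a ring, one extra carbon is not neutral: in this assay, methyl in place of hydrogen gives a number 13.3 percentage points lower from compound 3 to compound 4 (beyond the scatter) on an otherwise unchanged compound. Within the data shown here, the earlier compounds changed only the ring, so this is the first sign that the small alkyl group on the charged nitrogen also counts, and it leaves a number 6.4 percentage points lower from compound 2 to compound 4 (within the scatter) and a number 9.1 percentage points higher from compound 1 to compound 4 (within the scatter) as the remaining comparisons. Nothing available explains this drop. Open, on these data alone, is whether a propyl group would continue the trend, and whether ethyl in place of methyl on the five-membered ring of compound 2 acts the same way.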